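This account rests on a few compounds, and the source may have more. Where it says the series, first, only, none or still open, it means among the compounds named here.

Compounds measured so far:
- compound 1, `C=CCn1c(=O)n(C2CCC(CO)C2)c2nc(N)nc(O)c21` — 226 uM in a functional assay (B cells) with Mus musculus as the target; on this read-out higher numbers stand for an effect only at larger amounts of compound and lower numbers for an effect already at smaller amounts
- compound 2, `C=CCn1c(=O)n([C@H]2CO[C@@H](CO)C2)c2nc(N)nc(O)c21` — 83 uM in this assay
- compound 3, `C=CCn1c(=O)n(C2C=CC(CO)O2)c2nc(N)nc(O)c21` — 6 uM in this assay

All three share one core and differ only in the ring attached to an aromatic nitrogen. Compound 3 stands lowest of the three numbers: the step of a 14-fold lower number from compound 2 to compound 3 (1.14 log units; beyond the scatter) and the step of a 38-fold lower number from compound 1 to compound 3 (1.58 log units; beyond the scatter) are both beyond the scatter, and the step of a 2.7-fold lower number from compound 1 to compound 2 (0.44 log units; beyond the scatter) is more modest. Every change at this ring has therefore moved the read-out in this assay, and in each case a five-membered non-aromatic ring with one hetero atom gave the lower number.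

Compound 4, `C=CCn1c(=O)n(Cc2ccccc2)c2nc(N)nc(O)c21`, takes the step described as a group of 7 heavy atoms (7 carbon; one six-membered aromatic ring of carbon only) in place of a group of 7 heavy atoms (5 carbon, 2 oxygen; one five-membered non-aromatic ring with 1 hetero atom), on an aromatic nitrogen. The leaving group carried one hydrogen-bond donor and two hydrogen-bond acceptors; the entering benzyl carries none. Among the measured compounds shown here, no measured pair tests an aromatic ring at this position, so the three ring steps are the only guide, and they show that this position is sensitive. A worsening is expected, with the step estimated as a 10-fold higher number from compound 3 to compound 4 (1.00 log units; beyond the scatter). For compound 4 the value in this assay is estimated at 60 uM, with a range from 15 uM to 250 uM.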

Compound 4, concentration for half-maximal effect: 5 uM
Estimate against measurement, compound 4: 12-fold (1.08 log units) above, and the stated range ends above it.
By their numbers in this assay, from the lowest: compounds 4 and 3 (each within the scatter of the next); then compound 2; then compound 1.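

In this assay, the step of a 1.2-fold lower number from compound 3 to compound 4 (0.08 log units; within the scatter) shows that benzyl, with 0 hydrogen-bond donors and 0 hydrogen-bond acceptors, can stand on this aromatic nitrogen without the read-out leaving the level of compound 3, so neither a donor, nor an acceptor, nor a non-aromatic ring in this group is needed for a low number here. Benzyl also keeps the large distance from the two higher compounds, with the steps of a 17-fold lower number from compound 2 to compound 4 (1.22 log units; beyond the scatter) and a 45-fold lower number from compound 1 to compound 4 (1.66 log units; beyond the scatter), which means the earlier link between a five-membered non-aromatic ring with one hetero atom and a lower number does not hold as a rule: two very different groups now reach the same low level, and compound 2, which carries such a ring, stays well above them. The compounds shown give no measured property that could account for this result.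

On these data alone, it remains open whether the aromatic ring of benzyl matters at all, which a cyclohexylmethyl group or a pyridylmethyl group on the same nitrogen would test. The compounds also leave open how far the group tolerates a longer chain such as phenethyl, or a substituent such as a methoxy group or an amine on the benzyl ring.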